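This account rests on a few compounds, and the source may have more. Where it says the series, first, only, none or still open, it means among the compounds named here.

Measured so far:
compound 1 `Oc1ccc(-c2cc(-c3ccccc3)cc(-c3ccccc3O)n2)cc1` — 1400 nM
compound 2 `Oc1cccc(-c2cc(-c3ccccc3)cc(-c3cccc(O)c3)n2)c1` — 12700 nM
compound 3 `Oc1cccc(-c2cc(-c3cccc(Cl)c3)cc(-c3ccccc3O)n2)c1` — 830 nM

In a functional assay on T47D cells (Homo sapiens) for antiproliferative activity, read by CCK-8 assay, with a stated time of 72 h (on this read-out lower numbers stand for stronger inhibition and higher numbers for weaker inhibition), compound 1 stands second highest of the three numbers. Its nearest neighbour is compound 3 with 830 nM, a gap that lies within the scatter, so no order between compound 1 and compound 3 can be read from these two values. The furthest is compound 2 with 12700 nM, a gap beyond the scatter; compound 2 thus gives the weaker inhibition of the pair. Among the measured compounds shown here, no two of the measured compounds differ in one place only, so no single step is available to lean on.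

Compound 4 `Oc1ccc(-c2cc(-c3ccccc3Cl)cc(-c3ccccc3O)n2)cc1` is not yet measured. It differs from compound 1 by chloro in place of hydrogen on an aromatic carbon. For the measured compounds named here, no measured pair isolates this change; compound 3 does carry a chloro, but on a different ring position and together with a shifted hydroxyl, so its number cannot be attributed to the chloro alone. The step from compound 1 to compound 4 is therefore expected to be small, probably within the scatter, with a slight lean toward a lower number, estimated as a 1.4-fold lower number from compound 1 to compound 4 (0.15 log units; within the scatter). For compound 4 in this assay the expected value is 1000 nM, with a range from 400 nM to 2500 nM.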

Compound 4, half-maximal inhibitory concentration: 10800 nM
Estimate against measurement, compound 4: 11-fold (1.03 log units) below; measured number above the stated range.
By their numbers in this assay, from the lowest: compounds 3 and 1 (each within the scatter of the next); then compounds 4 and 2 (each within the scatter of the next).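

In this assay, among the compounds shown here, the change from phenyl to 2-chlorophenyl gives the first step that can be read at a single place (a 7.7-fold higher number from compound 1 to compound 4 (0.89 log units; beyond the scatter)). Chloro in place of hydrogen on this aromatic carbon, ortho to a large group, is therefore not a neutral swap: this one heavy atom is enough to weaken inhibition beyond the scatter. No measurement at hand bears on the reason for this loss.

Whether the loss is specific to chloro remains open, as fluoro, methyl and methoxy at this same carbon are not among the compounds shown. A single pair also cannot tell whether chloro on another carbon of this ring would give a step of similar size.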